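The source may hold more compounds than are shown below. What is called first, only, known or untested is meant among the compounds shown, and "the series" means these compounds.

Measured so far:
compound 1 `O=C(C1CCCCC1)N1CC(c2nc(-c3cccc(F)c3)no2)C1` — 1000 nM
compound 2 `CC1CCCC(C(=O)N2CC(c3nc(-c4cccc(Cl)c4)no3)C2)C1` — 410 nM

In an assay on HEK293 cells for positive allosteric modulation of metabotropic glutamate receptor 5 (Homo sapiens), read by FLIPR (a higher number here means that more compound is needed for the effect, a lower number that less compound is needed), compound 2 stands at the lowest of the two numbers; compound 1 sits at a higher number, and that gap is beyond the scatter. Within the data shown here, no step between measured compounds isolates the amide substituent, so the effect of swapping it is unknown here. Compound 3 `O=C(c1cccc(F)c1)N1CC(c2nc(-c3cccc(Cl)c3)no2)C1` carries 3-fluorophenyl in place of 3-methylcyclohexyl on a carbonyl carbon. Compound 3 is expected to give 700 nM, with a range of 250 nM to 2500 nM. The step of a 1.7-fold higher number from compound 2 to compound 3 (0.23 log units; within the scatter) is estimated as a small rise, likely inside the scatter.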

Compound 3, half-maximal effective concentration: > 10000 nM
Compound 3 ended at the assay's limit (the forecaster's own chance of this, stated with the estimate: 10%); middle value at least 14-fold (1.15 log units) away from the limit.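

At the carbonyl carbon on the amide-type nitrogen in a ring, 3-fluorophenyl in place of 3-methylcyclohexyl gives an at least 24-fold higher number from compound 2 to compound 3 (1.38 log units; beyond the scatter). The two groups match in heavy atoms, hydrogen-bond donors, hydrogen-bond acceptors and charge, yet this position does not accept the swap. Compound 3 stands at a limit of the assay, not at a number: the limit of > 10000 nM in this assay, at which 1 of the 3 values shown sits.

Open, from the compounds shown here alone, is whether the shift follows the aromatic ring or the fluorine, which an unsubstituted phenyl would separate. Also open, going by these compounds, is how an amine or a longer alkyl chain would read at this carbonyl carbon.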